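The source may report more compounds than this note shows. Statements on the series, on what has been measured and on what is new or still open speak of the compounds shown alone.

Among the compounds with values here, compound 2 `COc1ccccc1OCC(O)CNCCC(=O)Nc1ccc(C2=NNC(=O)CC2)cc1` is measured in a functional assay on the whole organism with Rattus norvegicus as the target (a lower number here means that less compound is needed, a higher number that more compound is needed for the effect), at 4.3 umol/kg, the lowest of the two numbers so far. Compound 1 `Cc1ccccc1OCC(O)CNCCC(=O)Nc1ccc(C2=NNC(=O)CC2)cc1` gives 6 umol/kg in this assay, and the step of a 1.4-fold lower number from compound 1 to compound 2 (0.14 log units; within the scatter) shows that the two lie within the scatter. Compound 3 `N#Cc1ccccc1OCC(O)CNCCC(=O)Nc1ccc(C2=NNC(=O)CC2)cc1` differs from compound 2 in one place: cyano in place of methoxy on an aromatic carbon. Within the data shown here, the only measured step changes a small group at the same aromatic carbon and stays within the scatter; no measured step involves a cyano group. For compound 3 the expected step is therefore a 1.2-fold higher number from compound 2 to compound 3 (0.07 log units; within the scatter), with the number estimated at 5 umol/kg, between 2.5 umol/kg and 10 umol/kg.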

Compound 3, dose for half-maximal effect: 1.7 umol/kg
Estimate against measurement, compound 3: 2.9-fold (0.47 log units) above; the measured number lies below the stated range.
By their numbers in this assay, from the lowest: compound 3; then compounds 2 and 1 (each within the scatter of the next).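

The earlier swap of methyl for methoxy at this aromatic carbon stayed within the scatter, so the position could have seemed indifferent to the group placed there. The cyano group changes that picture: in this assay it gives a 2.5-fold lower number from compound 2 to compound 3 (0.40 log units; beyond the scatter) and also a 3.5-fold lower number from compound 1 to compound 3 (0.55 log units; beyond the scatter) and these modest steps show that the group at this carbon can change the dose needed. Nothing available explains why cyano differs from the other two groups.

Going by these compounds, whether a chlorine atom, an amine or a carboxylic acid at this carbon would lower the number further remains open. So does whether cyano would give the same step on another carbon of the ring.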